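Morpholinylcarbonyl replaces cyano on the aryloxy chain

A few compounds are considered here, and "the series" means these few. Any claim that something is new, unique, unknown or untested is made for them only; others in the source may bear on it.

Compound 1 `CC(C)[C@H]1C(O)=C(C2=NS(=O)(=O)c3c(OCC(N)=O)cccc32)C(=O)N1Cc1ccccc1`: > 33000 nM
Compound 2 `CC(C)[C@H]1C(O)=C(C2=NS(=O)(=O)c3c(OCC#N)cccc32)C(=O)N1Cc1ccccc1`: > 33000 nM

The two measured compounds share one core and differ only at the saturated chain carbon bound to an oxygen on an aromatic ring. In an ADME assay on Huh-7 cells (Homo sapiens) for cytotoxicity, with a stated time of 72 h (a higher number here means that more compound is tolerated, a lower number that less compound is tolerated), compound 1 gives a limit of the assay rather than a number, > 33000 nM. In this assay compound 2 likewise gives a limit of the assay, > 33000 nM. The step that the two limits leave unreadable from compound 1 to compound 2 therefore cannot be read, since both values fall on (the limit of > 33000 nM in this assay, at which 2 of the 2 values shown sit).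

Compound 3 `CC(C)[C@H]1C(O)=C(C2=NS(=O)(=O)c3c(OCC(=O)N4CCOCC4)cccc32)C(=O)N1Cc1ccccc1` has not yet been measured; it differs from compound 2 by (morpholin-4-yl)carbonyl in place of cyano on a saturated chain carbon bound to an oxygen on an aromatic ring. Only the unreadable step bears on this change, so nothing in the data points to a step beyond the scatter in this assay, and compound 3 is expected to stay at the limit. Compound 3 is estimated at 33000 nM, with a range from 15000 nM to 100000 nM. This corresponds to an expected step of a number no higher from compound 2 to compound 3 (the limit leaves the size open).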

Compound 3, half-maximal cytotoxic concentration: > 33000 nM
Compound 3 gave a limit, no number; the forecaster's own chance of this, stated with the estimate: 85%; the middle value sits exactly at the limit.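

Compound 3 gives a limit of the assay, the value > 33000 nM in this assay and not a number. Going by these compounds alone, no step among compound 1, compound 2 and compound 3 can be read: the limit of > 33000 nM in this assay, at which 3 of the 3 values shown sit. The compounds shown leave open at what concentration any of the three becomes cytotoxic, and whether their chain groups differ in this respect.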